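The source may hold more compounds than are shown below. What is called first, only, known or untested is meant among the compounds shown, and "the series" means these compounds.

In a functional assay on MDA-MB-231 cells (Homo sapiens) for antiproliferative activity, read by MTT assay, with a stated time of 24 h (a lower number here means a stronger inhibitor, a higher number a weaker inhibitor), compound 1 `COc1ccccc1S(=O)(=O)N1CCN(c2nccc(Oc3cc(Cl)cc(Cl)c3)n2)CC1` gives 16800 nM. Compound 2 `O=S(=O)(c1ccc(F)cc1)N1CCN(c2nccc(Oc3cc(Cl)cc(Cl)c3)n2)CC1` gives > 50000 nM, which is a limit of the assay and not a number. Compound 3 `N#Cc1ccc(S(=O)(=O)N2CCN(c3nccc(Oc4cc(Cl)cc(Cl)c4)n3)CC2)cc1` differs from compound 2 by cyano in place of fluoro on an aromatic carbon, para to a large group. Going by the values given here, the only measured step at this sulfonyl substituent is an at least 2.9-fold higher number from compound 1 to compound 2 (0.47 log units; beyond the scatter), and it does not cover this exchange. No step beyond the scatter is therefore expected in this assay. The estimated step is an at least 1.2-fold lower number from compound 2 to compound 3 (0.09 log units; that floor lies within the scatter). Compound 3 is expected at 40000 nM, with an estimated range of 15000 nM to 90000 nM.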

Compound 3, half-maximal inhibitory concentration: 24800 nM
Estimate against measurement, compound 3: 1.6-fold (0.21 log units) above; the measured number falls inside the stated range.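

In this assay the exchange of fluoro for cyano reads as an at least 2.0-fold lower number from compound 2 to compound 3 (0.30 log units; that floor lies within the scatter) and so gives a floor, not a size. The value of compound 2 is a limit of the assay and not a number: the limit of > 50000 nM in this assay, at which 1 of the 3 values shown sits. Set against 2-methoxyphenyl, the 4-cyanophenyl group gives a 1.5-fold higher number from compound 1 to compound 3 (0.17 log units; within the scatter) and thus a measured value on the sulfonyl sulfur that is not separated from compound 1. Still open, on these data alone, are the true size of the fluoro to cyano step and how an amine or a carboxylic acid in place of cyano would read in this assay here.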